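Inverting two ring stereocentres in a cyclic integrin ligand

The compounds below may be only part of what the source reports. "The series", "measured", "known", "first", "only" and "open" are said of these compounds alone.

For the measured compounds named here, compound 2 `N=C(N)NCCC[C@@H]1NC(=O)CC(=O)N[C@H](CC(=O)O)C(=O)N[C@H](Cc2ccccc2)CNC1=O` is the only compound with a numerical result in an assay on K562 cells for inhibition of integrin alpha-5/beta-1 (Homo sapiens), with a stated time of 30 min; a lower number here means a stronger inhibitor, a higher number a weaker inhibitor: compound 2 gives 1300 nM. Compound 1 `N=C(N)NCCC[C@@H]1NC(=O)CC(=O)N[C@H](CC(=O)O)C(=O)N[C@@H](Cc2ccccc2)CNC1=O` gives only a limit of the assay, > 100000 nM. The change from compound 1 to compound 2 inverts a single stereocentre at a saturated ring carbon, and an at least 76-fold lower number from compound 1 to compound 2 (1.88 log units; beyond the scatter), a step that rests on the limit of > 100000 nM in this assay, at which 1 of the 2 values shown sits, and (the fact that one of compounds 1 and 2 is drawn with a defined configuration and the other without, at the place where they differ). Compound 3 `N=C(N)NCCC[C@H]1NC(=O)CC(=O)N[C@@H](CC(=O)O)C(=O)N[C@H](Cc2ccccc2)CNC1=O` keeps every atom and bond of compound 2 and changes only configuration: the two compounds have the same atoms and bonds; at least one stereo element is drawn with a configuration in one of them and without one in the other: 2 of 4 stereo elements differ; a stereocentre at a saturated ring carbon is drawn S in compound 2 and R in compound 3; a stereocentre at a saturated ring carbon is drawn R in compound 2 and S in compound 3. Going by the values given here, the one measured step shows that a single inversion in this core moves the number a long way. Two further inversions are therefore expected to move the number upward by a large step, a 23-fold higher number from compound 2 to compound 3 (1.36 log units; beyond the scatter), with a real chance that the assay returns only a limit. For compound 3 the estimate in this assay is 30000 nM, within 3000 nM to 100000 nM.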

Compound 3, half-maximal inhibitory concentration: > 100000 nM
Compound 3: only a limit was reported; the forecaster's own chance of this, stated with the estimate: 40%; middle value at least 3.3-fold (0.52 log units) from the limit.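

Inverting two ring stereocentres of compound 2 costs at least as much as the single inversion did, giving an at least 76-fold higher number from compound 2 to compound 3 (1.88 log units; beyond the scatter) in this assay. Two different sets of inversions from compound 2 have now both ended at a limit, so compound 2 remains the only one of the three stereoisomers with a numerical result, and the number depends on more than one stereocentre of the shared core. The true size of the new step stays unknown, and the step between compound 1 and compound 3 cannot be read, as both of their results are limits: the limit of > 100000 nM in this assay, at which 2 of the 3 values shown sit.

From the compounds shown here alone, whether any other arrangement of the four stereocentres would give a numerical result remains open. So does the effect of a longer chain carrying the carboxylic acid, or of an amine in place of the guanidine.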